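Bromine Moved Along the Ring, Toxicity Stays Beyond Reach

This account rests on a few compounds, and the source may have more. Where it says the series, first, only, none or still open, it means among the compounds named here.

Compound 1, `Cc1c(Cc2ccccc2Br)nc(SCc2ccc([N+](=O)[O-])cc2)[nH]c1=O`, gives >= 246000 nM in an ADME assay on MT4 cells (Homo sapiens) for cytotoxicity, read by MTT assay (on this read-out higher numbers stand for lower toxicity in this test and lower numbers for higher toxicity in this test), a limit of the test rather than a number.
Compound 2, `Cc1c(Cc2cccc(Br)c2)nc(SCc2ccc([N+](=O)[O-])cc2)[nH]c1=O`, gives > 280000 nM in this assay, again a limit.
Compound 3, `CCc1c(Cc2ccccc2Br)nc(SCc2ccc([N+](=O)[O-])cc2)[nH]c1=O`, gives > 272000 nM in this assay, also a limit.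

Compound 3 therefore stands at a limit, and so do the two other measured compounds; none of the three can be ranked against another, and no change can be read between them. The change from compound 3 to compound 4, `CCc1c(Cc2cccc(Br)c2)nc(SCc2ccc([N+](=O)[O-])cc2)[nH]c1=O`, is 3-bromophenyl in place of 2-bromophenyl on a saturated chain carbon bound to an aromatic carbon. The same change has been made once before, from compound 1 to compound 2, where a step that the two limits leave unreadable from compound 1 to compound 2; that step stays unreadable because the limit of >= 246000 nM in this assay, at which 1 of the 3 values shown sits, and the limit of > 280000 nM in this assay, at which 1 of the 3 values shown sits, both sit at the edge of the test. The step from compound 3 to compound 4 in this assay is thus expected to show nothing beyond the scatter, and most likely to end at a limit again, as a number no higher from compound 3 to compound 4 (the limit leaves the size open). Compound 4 is estimated at 270000 nM, within 150000 nM to 600000 nM.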

Compound 4, half-maximal cytotoxic concentration: 187000 nM
Compound 4: the middle estimate sits 1.4-fold (0.16 log units) above what was measured; the range from low to high includes it.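

In this assay, among the compounds shown here, compound 4 gives 187000 nM, the first value in this set that is a number and not a limit, so 3-bromophenyl in place of 2-bromophenyl at this position can now be given a direction, though only as a floor: an at least 1.4-fold lower number from compound 3 to compound 4 (0.16 log units; that floor lies within the scatter). Methyl in place of hydrogen on the saturated chain carbon can be read in the same limited way: an at least 1.4-fold lower number from compound 2 to compound 4 (0.17 log units; that floor lies within the scatter). Neither floor shows a change beyond the scatter, and the steps among compounds 1, 2 and 3 still cannot be read.

On these data alone, the true size of both steps stays open, since each starts from a limit. As far as these compounds go, what a longer chain such as propyl, or an amine in place of the bromine, would do in this assay also remains open.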